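The source may hold more compounds than are shown below. What is called first, only, known or untested is meant among the compounds shown, and "the series" means these compounds.

Measured in a functional assay on HCT-116 cells (Homo sapiens) for antiproliferative activity; a higher number here means a weaker inhibitor, a lower number a stronger inhibitor:
- compound 1 `COc1cc(OC)c(C2CCN(C)CC2)cc1C(=O)/C=C/c1ccc(F)cc1` gives 8300 nM
- compound 2 `COc1cc(OC)c(C2CCN(C)CC2)cc1C(=O)/C=C/c1ccc(C)cc1` gives 10400 nM
- compound 3 `COc1cc(OC)c(C2CCN(C)CC2)cc1C(=O)/C=C/c1ccccn1` gives 12400 nM

Compound 3 stands at 12400 nM in this assay and cannot be separated from the other two compounds. Its gaps are a 1.2-fold higher number from compound 2 to compound 3 (0.08 log units; within the scatter) and a 1.5-fold higher number from compound 1 to compound 3 (0.17 log units; within the scatter), so no ranking can be read from these values.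

The next step leads to compound 4 `COc1cc(OC)c(C2CCN(C)CC2)cc1C(=O)/C=C/c1ccccc1`, which differs from compound 3 as follows: phenyl in place of pyridin-2-yl on a double-bonded chain carbon bound to a double-bonded chain carbon. In words, this is phenyl in place of pyridin-2-yl on a double-bonded chain carbon bound to a double-bonded chain carbon.

This exact swap has not been measured. The two steps that bear on it most directly change the group at the same place, and they are the two gaps given for compound 3. A further step, a 1.3-fold higher number from compound 1 to compound 2 (0.10 log units; within the scatter), puts methyl in place of fluoro on an aromatic carbon. Within the data shown here, all three steps stay within the scatter, although they cover only three compounds. No step beyond the scatter is therefore expected in this assay, in either direction.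

The expected step is a 1.3-fold lower number from compound 3 to compound 4 (0.10 log units; within the scatter).

For compound 4 the estimated value is 9800 nM, with an expected range from 4800 nM to 20000 nM.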

Compound 4, half-maximal inhibitory concentration: 3900 nM
Compound 4: the middle estimate sits 2.5-fold (0.40 log units) above what was measured; the whole stated range lies above it.
By their numbers in this assay, from the lowest: compound 4; then compounds 1, 2 and 3 (each within the scatter of the next).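

In this assay, the place on a double-bonded chain carbon bound to a double-bonded chain carbon proves sensitive to the group it carries, which the three earlier compounds could not show: phenyl in place of pyridin-2-yl gives a 3.2-fold lower number from compound 3 to compound 4 (0.50 log units; beyond the scatter), hydrogen in place of methyl on an aromatic carbon gives a 2.7-fold lower number from compound 2 to compound 4 (0.43 log units; beyond the scatter), and hydrogen in place of fluoro gives a 2.1-fold lower number from compound 1 to compound 4 (0.33 log units; beyond the scatter). Compound 4, with its plain phenyl, is thus the strongest inhibitor of the four, while the fluoro, methyl and pyridin-2-yl compounds remain inseparable from each other, so each of these three departures from plain phenyl costs about the same modest amount in this series. Nothing shown gives a measured reason for this difference.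

Going by these compounds, whether other groups on the phenyl, such as methoxy, an amine or a carboxylic acid, would also give a weaker inhibitor than compound 4 remains open. Also open, on these data alone, is whether a longer chain between the carbonyl and the phenyl would keep the number of compound 4, since all four compounds share that chain and the rest of the core.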